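Fluoro for chloro on the sulfonyl ring: compound 4

The source may report more compounds than this note shows. Statements on the series, on what has been measured and on what is new or still open speak of the compounds shown alone.

Measured so far:
Compound 1, `N#C/C(=C\c1ccccc1OS(=O)(=O)c1ccc(Cl)cc1)C(=O)Nc1nnc(Cc2cccc3ccccc23)s1`, gives 15% in a functional assay on HL-60 cells (Homo sapiens) for inhibition, read by CCK-8 assay, with a stated time of 48 h, tested at 20 uM; on this read-out higher numbers stand for more inhibition of growth at the one concentration tested and lower numbers for less inhibition of growth.
Compound 2, `N#C/C(=C\c1ccccc1OS(=O)(=O)c1ccc(F)cc1)C(=O)Nc1nnc(Cc2cccc3ccccc23)s1`, gives 12% in this assay.
Compound 3, `N#C/C(=C\c1ccccc1OS(=O)(=O)c1ccc(Cl)cc1)C(=O)Nc1nnc(Cc2ccc(F)cc2)s1`, gives 20% in this assay.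

Compound 2 differs from compound 1 only by fluoro in place of chloro on an aromatic carbon; the step in this assay is a number 3 percentage points lower from compound 1 to compound 2 (within the scatter). Compound 3 differs from compound 1 by 4-fluorophenyl in place of naphthalen-1-yl on a saturated chain carbon bound to an aromatic carbon, with a step of a number 5 percentage points higher from compound 1 to compound 3 (within the scatter). Compound 3 and compound 2 have not been compared by a counted step; their values differ by an amount within the usual scatter.

Compound 4, `N#C/C(=C\c1ccccc1OS(=O)(=O)c1ccc(F)cc1)C(=O)Nc1nnc(Cc2ccc(F)cc2)s1`, is not yet measured. It differs from compound 3 by fluoro in place of chloro on an aromatic carbon, the same change as between compound 1 and compound 2, at the same place. The step from compound 3 to compound 4 in this assay is expected to be a number 3 percentage points lower from compound 3 to compound 4 (within the scatter), resting on the earlier step of a number 3 percentage points lower from compound 1 to compound 2 (within the scatter) in the core of compound 1. Compound 4 is estimated at 17%, with a range from 8% to 26%.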

Compound 4, percent growth inhibition at one concentration: 13%
The estimate for compound 4 lay 4 percentage points above the measured number, within the range that was stated.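

In this assay, fluoro in place of chloro on the sulfonyl-bearing aromatic ring gives a number 7 percentage points lower from compound 3 to compound 4 (within the scatter), and this agrees with the earlier step: the same change on two cores in this assay, a number 3 percentage points lower (within the scatter) from compound 1 to compound 2 and a number 7 percentage points lower (within the scatter) from compound 3 to compound 4, 4 percentage points apart, within the scatter of two such steps. On the other side of the shared core, 4-fluorophenyl in place of naphthalen-1-yl gives a number 1 percentage points higher from compound 2 to compound 4 (within the scatter), which also agrees with its earlier counterpart: the same change on two cores in this assay, a number 5 percentage points higher (within the scatter) from compound 1 to compound 3 and a number 1 percentage points higher (within the scatter) from compound 2 to compound 4, 4 percentage points apart, within the scatter of two such steps. Going by these compounds alone, neither change differs measurably between the two cores, but every step here lies within the scatter, so this agreement shows only that neither change has a detectable effect on either core, not that a real effect transfers from one core to the other.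

The compounds shown leave open whether a methoxy or trifluoromethyl group in place of the halogen on the sulfonyl-bearing ring would move growth inhibition beyond the scatter. The same question stands for an amine or a carboxylic acid in place of the 4-fluorophenyl or naphthalen-1-yl group.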